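This account rests on a few compounds, and the source may have more. Where it says the series, first, only, none or still open, it means among the compounds named here.

Measured so far: compound 1 `CNC(=O)c1cc(Oc2ccc(NC(=O)c3nn(-c4ccccc4OC(F)(F)F)c(=O)cc3C)cc2F)ccn1` and compound 2 `Cc1cc(=O)n(-c2ccc(Br)cc2F)nc1C(=O)Nc1ccc(Oc2ncnc3ccsc23)cc1`.

In a functional assay on HepG2 cells (Homo sapiens) for cytotoxicity, read by MTT assay, with a stated time of 72 h (on this read-out higher numbers stand for weaker inhibition and lower numbers for stronger inhibition), compound 1 reaches only a limit, > 40000 nM, which is not a number. In this assay, going by the values given here, compound 2 gives 10600 nM, the only number among the two values shown. The other value, that of compound 1, sits at the limit, as the limit of > 40000 nM in this assay, at which 1 of the 2 values shown sits, records. Compound 3 `Cc1cc(=O)n(-c2ccc(F)cc2)nc1C(=O)Nc1ccc(Oc2ncnc3ccsc23)cc1` has not yet been measured; it differs from compound 2 by 4-fluorophenyl in place of 4-bromo-2-fluorophenyl on an aromatic nitrogen. Among the compounds with values here, no step between two measured compounds is known, so the step is expected to stay within the scatter, with a slight lean toward weaker inhibition. Compound 3 is expected to give 15000 nM (range 5000 nM to 45000 nM), a step of a 1.4-fold higher number from compound 2 to compound 3 (0.15 log units; within the scatter).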

Compound 3, half-maximal inhibitory concentration: 2110 nM
For compound 3 the middle estimate is 7.1-fold (0.85 log units) above the measured one; the measured number lies below the stated range.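

In this assay, going by these compounds alone, swapping 4-bromo-2-fluorophenyl for 4-fluorophenyl on the aromatic nitrogen gives a 5.0-fold lower number from compound 2 to compound 3 (0.70 log units; beyond the scatter) and so provides the first step that lies beyond the scatter. The earlier compounds shown here offered no such comparison, so this position now stands as one where the read-out responds to the group placed there. Nothing shown here accounts for the step.

As far as these compounds go, whether the step belongs to the bromine or to the fluorine of the leaving group stays open. So does the reading of a phenyl ring carrying an amine or a carboxylic acid at this position.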